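The source may report more compounds than this note shows. Statements on the series, on what has been measured and on what is new or still open speak of the compounds shown alone.

Measured compounds in a functional assay on HeLa cells (Homo sapiens) for inhibition, read by sulforhodamine B assay, with a stated time of 48 h; on this read-out lower numbers stand for stronger inhibition of growth and higher numbers for weaker inhibition of growth:
compound 1 `COC(=O)[C@@]1(C)CCC=C2[C@@H]1CC[C@@H](C)[C@]2(C)Cc1c[nH]c2ccccc12` gives 3600 nM;
compound 2 `COC(=O)[C@@]1(C)CCC=C2[C@@H]1CC[C@@H](C)[C@]2(C)Cc1c[nH]c2ccc(F)cc12` gives 3700 nM.

Compound 1 holds the lower of the two numbers in this assay, but its nearest neighbour compound 2 sits within the scatter of it, so no order between the two can be read. Within the data shown here, the one measured step, a 1.0-fold higher number from compound 1 to compound 2 (0.01 log units; within the scatter), is the only guide available for substitution on the six-membered ring of the shared core.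

Compound 3 `COC(=O)[C@@]1(C)CCC=C2[C@@H]1CC[C@@H](C)[C@]2(C)Cc1c[nH]c2c(C)cccc12` differs from compound 1 by methyl in place of hydrogen on an aromatic carbon. The step from compound 1 to compound 2 bears on it only loosely, as it concerns a different group entering at a different place of the same ring; it was within the scatter. Among the measured compounds shown here, no methyl step on this ring has been measured. On that basis no step beyond the scatter is expected in this assay, in either direction, giving an expected no change at the digits printed from compound 1 to compound 3 (within the scatter). Compound 3 is therefore estimated at 3600 nM, within a range of 1500 nM to 9000 nM.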

Compound 3, concentration for 50% growth inhibition: 4900 nM
For compound 3 the middle estimate is 1.4-fold (0.13 log units) below the measured one, and the stated range covers the measured number.
By their numbers in this assay, from the lowest: compounds 1, 2 and 3 (each within the scatter of the next).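

In this assay, methyl in place of hydrogen on an aromatic carbon, ortho to a fused ring and meta to a fused ring, gives a 1.4-fold higher number from compound 1 to compound 3 (0.13 log units; within the scatter). Among these compounds, this is the first methyl step on this six-membered aromatic ring, and it shows that this position accepts one added carbon with the number staying within the scatter of compound 1. Alongside a 1.0-fold higher number from compound 1 to compound 2 (0.01 log units; within the scatter), it makes two substitutions on this ring, at different places, without a step beyond the scatter, and no evidence available here bears on the reason for this result.

As far as these compounds go, whether an amine, a carboxylic acid or a longer chain at this position would also stay within the scatter remains open. Also open, from the compounds shown here alone, is how methyl would read at the place carrying fluoro in compound 2.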